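A few compounds are considered here, and "the series" means these few. Any claim that something is new, unique, unknown or untested is made for them only; others in the source may bear on it.

Measured in a functional assay on DU-145 cells (Homo sapiens) for inhibition, read by trypan blue exclusion, with a stated time of 96 h; on this read-out lower numbers stand for stronger inhibition of growth and higher numbers for weaker inhibition of growth:

- compound 1 `O=C(/C(=C\c1ccccc1OCc1ccccc1)Sc1ccc(F)cc1)c1ccc(Cl)cc1`: 1000 nM
- compound 2 `O=C(/C(=C\c1ccccc1OCc1ccccc1)S(=O)(=O)c1ccc(F)cc1)c1ccc(Cl)cc1`: 1000 nM
- compound 3 `O=C(/C(=C\c1ccccc1OCc1ccccc1)SCc1ccc(Cl)c(Cl)c1)c1ccc(Cl)cc1`: 10000 nM

Compound 3, at 10000 nM, has the highest number of the three and is the weakest inhibitor of growth in the set. Compound 4 `COc1ccc(S/C(=C/c2ccccc2OCc2ccccc2)C(=O)c2ccc(Cl)cc2)cc1` has not yet been measured. It has 4-methoxyphenyl in place of 3,4-dichlorobenzyl on a sulfur.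

The closest measured comparison is the step of a 10-fold higher number from compound 1 to compound 3 (1.00 log units; beyond the scatter), where 3,4-dichlorobenzyl replaces 4-fluorophenyl on the same sulfur. The step of a 10-fold higher number from compound 2 to compound 3 (1.00 log units; beyond the scatter) is of the same size, while the step of no change at the digits printed from compound 1 to compound 2 (within the scatter) shows no separation between the sulfanyl and sulfonyl compounds. Going by the values given here, compound 4 resembles compound 1 in carrying a substituted phenyl on that sulfur, although no measured compound shows the effect of exchanging 4-fluorophenyl for 4-methoxyphenyl. The expected change is therefore a reversal of the step seen with compound 1, a 10-fold lower number from compound 3 to compound 4 (1.00 log units; beyond the scatter), toward a lower number in this assay. For compound 4 the estimated value is 1000 nM, with an expected range of 300 nM to 4000 nM.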

Compound 4, concentration for 50% growth inhibition: 1000 nM
Compound 4: middle estimate and measured number agree at the digits printed; measured number inside the range.
By their numbers in this assay, from the lowest: compounds 1, 2 and 4 (each within the scatter of the next); then compound 3.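

In this assay, methoxy in place of fluoro on an aromatic carbon gives no change at the digits printed from compound 1 to compound 4 (within the scatter), so this exchange on the phenyl ring carried by the sulfur does not separate the two compounds. With 4-methoxyphenyl in place of 3,4-dichlorobenzyl on the same sulfur, the result is a 10-fold lower number from compound 3 to compound 4 (1.00 log units; beyond the scatter), which means that the gap to compound 3 now appears with a second substituted phenyl group and not only with 4-fluorophenyl. The sulfonyl comparison adds no change at the digits printed from compound 2 to compound 4 (within the scatter), so compound 4 also stays level with the sulfonyl compound.

On these data alone, whether the gap follows the benzyl link or the two chlorines remains open, and a 4-fluorobenzyl group on the sulfur would separate these two readings. No supporting evidence bears on why compound 3 stands apart.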